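The compounds below may be only part of what the source reports. "The series", "measured", "known", "first", "only" and "open" are said of these compounds alone.

Compound 3 `CCCCCC(=O)Nc1cc2nc(C3CCCCC3)[nH]c2cc1N(CC)CC` carries no number in an ADME assay on Vero cells (Chlorocebus sabaeus) for cytotoxicity, read by resazurin assay, with a stated time of 3 days (on this read-out lower numbers stand for stronger inhibition and higher numbers for weaker inhibition), where compound 3 is recorded as "not determined" (no result reported). The two measured compounds offer only limits of that assay. Compound 1 `CCCCNC(=O)Nc1cc2nc(C3CCCCC3)[nH]c2cc1N(CC)CC` sits at the limit of > 100 ug/mL in this assay. Compound 2 `CCN(CC)c1cc2[nH]c(C3CCCCC3)nc2cc1NC(=O)c1cnccn1` likewise sits at the limit of > 100 ug/mL in this assay. The change a step that the two limits leave unreadable from compound 1 to compound 2 therefore cannot be sized. Compound 4 `CCN(CC)c1cc2[nH]c(C3CCCCC3)nc2cc1NC(=O)c1ccc(OC(F)F)cc1` differs from compound 3 by 4-(difluoromethoxy)phenyl in place of pentyl on a carbonyl carbon. For the measured compounds named here, no measured step mirrors this change, and the only guide is the limit of > 100 ug/mL in this assay, at which 2 of the 3 values shown sit, on which both measured compounds rest. On that basis compound 4 is expected to show similarly weak cytotoxicity in this assay, with an estimate of 100 ug/mL and a range from 30 ug/mL to 300 ug/mL.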

Compound 4, half-maximal inhibitory concentration: > 100 ug/mL
Compound 4 gave a limit, no number; the forecaster's own chance of this, stated with the estimate: 70%; the middle value sits exactly at the limit.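

In this assay, for the compounds shown here, no step among compound 1, compound 2 and compound 4 can be read, since each rests at a limit and not at a number: the limit of > 100 ug/mL in this assay, at which 3 of the 4 values shown sit. Where the true value of each of these compounds lies stays open.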